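Replacing the 2-cyanophenyl arm of compound 2 with isobutyl

The source may report more compounds than this note shows. Statements on the series, on what has been measured and on what is new or still open speak of the compounds shown alone.

Two compounds have numbers in an in vitro functional assay on cells for agonist activity at Bombesin receptor subtype-3 (Homo sapiens), read by luminescence and calcium flux (on this read-out lower numbers stand for an effect already at smaller amounts and higher numbers for an effect only at larger amounts of compound), so far. Compound 2 `N#Cc1ccccc1Cc1cnc(CCc2ccc(-c3ccccc3C(=O)O)cc2)[nH]1` gives 5480 nM, the higher of the two; compound 1 `CCCCc1cnc(C(CCCO)Cc2ccc(-c3ccccc3C(=O)O)cc2)[nH]1` gives 1900 nM, a lower number beyond the usual scatter. Compound 3 `CC(C)CCc1cnc(CCc2ccc(-c3ccccc3C(=O)O)cc2)[nH]1` differs from compound 2 by isobutyl in place of 2-cyanophenyl on a saturated chain carbon bound to an aromatic carbon. Going by the values given here, no measured pair shows this exact change, but compound 1, which carries only carbon chains on its core, stands lower at 1900 nM, so a modest gain is expected, as a 2.1-fold lower number from compound 2 to compound 3 (0.32 log units; beyond the scatter). Compound 3 is estimated at 2600 nM, with a range from 1000 nM to 6500 nM.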

Compound 3, half-maximal effective concentration: 119 nM
Compound 3: the middle estimate sits 22-fold (1.34 log units) above what was measured; the whole stated range lies above it.
By their numbers in this assay, from the lowest: compound 3; then compound 1; then compound 2.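

Within this assay, isobutyl in place of 2-cyanophenyl gives a 46-fold lower number from compound 2 to compound 3 (1.66 log units; beyond the scatter) and shows that this position on a saturated chain carbon bound to an aromatic carbon responds strongly to the group it carries. The aromatic ring and nitrile of the 2-cyanophenyl arm are not required for a low number here, but they leave together, so this step cannot divide the gain between them. No measurement here accounts for the size of the step. Still open, going by these compounds, is whether plain phenyl, cyclohexyl or a longer chain at this place keeps the number as low.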